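Cytotoxicity of a Shared Core: Expecting Compound 3

The source may report more compounds than this note shows. Statements on the series, on what has been measured and on what is new or still open speak of the compounds shown alone.

Measured in a functional assay on WI-38 VA13 cells (Homo sapiens) for cytotoxicity; a lower number here means that less compound is needed, a higher number that more compound is needed for the effect:
Compound 1 `O=C(Nc1ccc2nc(NC(=O)C3CCCCC3)sc2c1)c1ccccc1Cl` gives 0.025 ug/mL.
Compound 2 `O=C(Nc1ccc2nc(NC(=O)C3CC3)sc2c1)c1c(Cl)cccc1Cl` gives 0.013 ug/mL.

Compound 2 has the lower of the two numbers, but its distance from compound 1 lies within the usual scatter of this assay, so the two cannot be told apart by these measurements. Both share the same core, and the two compounds differ in more than one place, so no single change can be read from them.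

Compound 3 `CCCCNC(=O)Nc1nc2ccc(NC(=O)c3c(Cl)cccc3Cl)cc2s1` has not yet been measured. It differs from compound 2 in one place: butylamino in place of cyclopropyl on a carbonyl carbon. For the measured compounds named here, no measured pair of compounds shows this kind of change, so there is nothing here to tell how large a step it brings. A step is expected to be small, if present at all, with a slight lean towards a higher number in this assay, but one that may well stay within the scatter, and this is what a 1.5-fold higher number from compound 2 to compound 3 (0.19 log units; within the scatter) is estimated to mean. For compound 3 the expected value in this assay is 0.02 ug/mL, with a range from 0.006 ug/mL to 0.07 ug/mL.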

Compound 3, half-maximal effective concentration: 0.028 ug/mL
Compound 3: middle estimate off by 1.4-fold (0.15 log units), on the low side; the measured number falls inside the stated range.
By their numbers in this assay, from the lowest: compounds 2, 1 and 3 (each within the scatter of the next, the first and the last beyond it).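

For the compounds shown here, this is the first pair that differs in only one place, so a single change can now be read. In this assay, butylamino in place of cyclopropyl on a carbonyl carbon gives a 2.2-fold higher number from compound 2 to compound 3 (0.33 log units; beyond the scatter), a modest step showing that this position is not wholly indifferent to what sits on it. The change replaces a small carbon ring with an open chain and turns a (cyclopropylcarbonyl)amino group into a (butylcarbamoyl)amino group, which brings in a nitrogen and a hydrogen-bond donor, but nothing shown here explains why the number moves.

The compounds shown leave open which part of the change goes with the step: the lost ring, the added nitrogen or the open chain, all of which arrive together in this one pair. A cyclopropylamino group on the same carbonyl carbon would keep both the ring and the nitrogen, and a pentyl chain there would keep an open chain without the nitrogen, so these two groups could separate those parts.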